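The source may hold more compounds than are shown below. What is called first, only, known or untested is meant among the compounds shown, and "the series" means these compounds.

Measured so far in an in vitro ADME assay on microsomes from liver (Homo sapiens) for metabolic stability, read by LC-MS; a higher number here means that the compound lasts longer, a lower number that the compound disappears faster:
- compound 1 `N#Cc1ccccc1Cn1c(N2CCC[C@@H](N)C2)ncc(/C=C/c2ccc(F)cc2)c1=O`: 3.1 h
- compound 2 `N[C@@H]1CCCN(c2cc(=O)[nH]c(=O)n2Cc2ccccc2Br)C1`: > 3.33 h
- compound 3 `Cn1c(=O)cc(N2CCC[C@@H](N)C2)n(Cc2ccccc2Br)c1=O`: > 3.33 h

Compound 3 stands at > 3.33 h, which is a limit of the assay and not a number. Compound 2 gives > 3.33 h, also only a limit. Across the series, the position is the limit of > 3.33 h in this assay, at which 2 of the 3 values shown sit. Compound 1 alone has a true number, 3.1 h.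

Compound 4 `Cn1c(=O)cc(N2CCC[C@@H](N)C2)n(Cc2cc(F)ccc2Cl)c1=O` follows from compound 3 by one change: 2-chloro-5-fluorophenyl in place of 2-bromophenyl on a saturated chain carbon bound to an aromatic nitrogen. In words, 2-chloro-5-fluorophenyl takes the place of 2-bromophenyl on a saturated chain carbon bound to an aromatic nitrogen.

Among the measured compounds shown here, the only measured step, a step that the two limits leave unreadable from compound 2 to compound 3, is methyl in place of hydrogen on an aromatic nitrogen. For the measured compounds named here, it has no readable size and lies at a different place, so no measured step bears directly on this change. The expectation therefore rests on compound 3, whose > 3.33 h is a limit. No step beyond the scatter is expected in this assay, and no direction can be given for the estimated a number no higher from compound 3 to compound 4 (the limit leaves the size open). The expected value for compound 4 is 3.3 h, with an estimated range of 1.6 h to 5 h.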

Compound 4, half-life: > 3.33 h
Compound 4 ended at the assay's limit; the forecaster's own chance of this, stated with the estimate: 60%; middle value at least 1.0-fold (0.00 log units) away from the limit.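

In this assay compound 4 gives > 3.33 h, a limit and not a number. No new step can be read between compound 3 and compound 4, as both sit at this limit: the limit of > 3.33 h in this assay, at which 3 of the 4 values shown sit.

The compounds shown leave open whether 2-chloro-5-fluorophenyl and 2-bromophenyl differ at all in half-life.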